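Furan in place of methoxyphenyl on a fused bicyclic core

The source may report more compounds than this note shows. Statements on the series, on what has been measured and on what is new or still open speak of the compounds shown alone.

Measured compounds:
compound 1 `Nc1nc(Br)cn2cc(-c3ccco3)nc12` — 210 nM
compound 2 `Nc1nc(-c2ccccc2)cn2cc(-c3ccccc3)nc12` — 180 nM
compound 3 `COc1ccc(-c2cn3cc(-c4ccccc4)nc(N)c3n2)cc1` — 524 nM

Compound 3 gives the highest number of the three in an assay on cells for displacement of a labelled ligand from adenosine receptor A1 (Homo sapiens), read by scintillation counting, with a stated time of 120 min; on this read-out lower numbers stand for stronger inhibition and higher numbers for weaker inhibition. Its nearest neighbour is compound 1, and the gap to compound 2 is the largest. Within the data shown here, the only single-point step among the measured compounds, a 2.9-fold higher number from compound 2 to compound 3 (0.46 log units; beyond the scatter), is a modest rise that lies beyond the scatter.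

Compound 4 `Nc1nc(-c2ccccc2)cn2cc(-c3ccco3)nc12` has not yet been measured. It differs from compound 3 by furan-2-yl in place of 4-methoxyphenyl on an aromatic carbon. Among the measured compounds shown here, no measured pair isolates the exchange of a phenyl for a furan-2-yl; compound 1 and compound 2 differ in two places at once, and their values in this assay sit within the scatter of each other. The step from compound 2 to compound 3 shows that the methoxy is what raised the number, and compound 4 has no methoxy. Compound 4 is therefore expected to lose that rise, so a step of about a 2.4-fold lower number from compound 3 to compound 4 (0.38 log units; beyond the scatter) downward is expected, back toward the values of compound 1 and compound 2. Compound 4 is estimated at 220 nM, with a range of 100 nM to 500 nM.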

Compound 4, inhibition constant: 143 nM
For compound 4 the middle estimate is 1.5-fold (0.19 log units) above the measured one; measured number inside the range.
By their numbers in this assay, from the lowest: compounds 4, 2 and 1 (each within the scatter of the next); then compound 3.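

In this assay, on the aromatic carbon of the five-membered aromatic ring with 2 nitrogen, replacing phenyl with furan-2-yl gives a 1.3-fold lower number from compound 2 to compound 4 (0.10 log units; within the scatter), so the two groups cannot be told apart at this place. Among these compounds, the exchange of 4-methoxyphenyl for furan-2-yl gives a 3.7-fold lower number from compound 3 to compound 4 (0.56 log units; beyond the scatter), which makes 4-methoxyphenyl the one group of the three at this place whose number stands apart from the others. With furan-2-yl held constant, the exchange of bromo for phenyl on the core gives a 1.5-fold lower number from compound 1 to compound 4 (0.17 log units; within the scatter), so these two groups also cannot be told apart, and no supporting data are available to explain any of these steps.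

The compounds shown leave open whether the higher number of compound 3 is specific to methoxy or would also appear with a methyl, a chlorine or a hydroxyl on that phenyl ring. They also leave open how a thiophene or a pyridine would compare with furan-2-yl at this place, and whether the amine on the shared core could be exchanged for an acetamide.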